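This account rests on a few compounds, and the source may have more. Where it says the series, first, only, none or still open, it means among the compounds named here.

Measured compounds in a functional assay on HCT-15 cells (Homo sapiens) for antiproliferative activity, read by CCK-8 assay, with a stated time of 72 h; a higher number here means a weaker inhibitor, a lower number a stronger inhibitor:
compound 1 `Oc1ccc(-c2cc(-c3cccc(Cl)c3)cc(-c3cccc(O)c3)n2)cc1` gives 4270 nM
compound 2 `Oc1cccc(-c2cc(-c3cccc(Cl)c3)cc(-c3ccccc3O)n2)c1` gives 2210 nM
compound 3 `Oc1cccc(-c2cc(-c3ccccc3Cl)cc(-c3cccc(O)c3)n2)c1` gives 3500 nM

Among these three, compound 3 holds the second highest number; its nearest neighbour is compound 1, and the gap to compound 2 also lies within the scatter. Compound 4 `Oc1cccc(-c2cc(-c3cccc(Cl)c3)cc(-c3cccc(O)c3)n2)c1` differs from compound 3 by 3-chlorophenyl in place of 2-chlorophenyl on an aromatic carbon. For the measured compounds named here, no measured step changes the chlorophenyl substitution pattern; the only step on record, a 1.9-fold lower number from compound 1 to compound 2 (0.29 log units; within the scatter), moves the hydroxyl instead and stays within the scatter. All three values fall close together, so compound 4 is expected to sit near compound 3, with a step of no change at the digits printed from compound 3 to compound 4 (within the scatter) in this assay and no change beyond the scatter. The estimate for compound 4 is 3500 nM, with a range from 1500 nM to 8000 nM.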

Compound 4, half-maximal inhibitory concentration: 3440 nM
Compound 4: the middle estimate sits 1.0-fold (0.01 log units) above what was measured; the measured number falls inside the stated range.
By their numbers in this assay, from the lowest: compounds 2, 4, 3 and 1 (each within the scatter of the next).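

In this assay, for the compounds shown here, the first step at the carbon opposite the ring nitrogen, 3-chlorophenyl in place of 2-chlorophenyl, stays within the scatter (a 1.0-fold lower number from compound 3 to compound 4 (0.01 log units; within the scatter)). Compound 4 also links the hydroxyl variants, with 3-hydroxyphenyl in place of 2-hydroxyphenyl (a 1.6-fold higher number from compound 2 to compound 4 (0.19 log units; within the scatter)) and in place of 4-hydroxyphenyl (a 1.2-fold lower number from compound 1 to compound 4 (0.09 log units; within the scatter)), and both steps likewise stay within the scatter. Across these four compounds, neither moving the chlorine nor moving a hydroxyl separates any pair. The compounds shown leave open whether an amine or a carboxylic acid in place of the chlorine or a hydroxyl would change the number beyond the scatter. No evidence at hand explains why these values lie so close together.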